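Ether variation on the aryl side: half-life notes

A few compounds are considered here, and "the series" means these few. Any claim that something is new, unique, unknown or untested is made for them only; others in the source may bear on it.

Measured so far in an ADME assay; a lower number here means that the compound disappears faster, a higher number that the compound lasts longer:
compound 1, `COc1ccc(C[S+]([O-])c2ncccc2C(=O)Nc2ccncc2)c(OC)c1OC`: 0.45 h.
compound 2, `COCOCCOc1cc(OC)ccc1C[S+]([O-])c1ncccc1C(=O)Nc1ccncc1`: a limit of the assay, < 0.02 h.

Compound 2 stands at the lower edge of what has been measured; its result is a limit of the assay and not a number, as stated in the limit of < 0.02 h in this assay, at which 1 of the 2 values shown sits. Among the compounds with values here, compound 1 gives the only fixed number in this assay and is the sole anchor for the series. Compound 3, `CCOc1cc(OC)ccc1C[S+]([O-])c1ncccc1C(=O)Nc1ccncc1`, is not yet measured. It differs from compound 2 in one place: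

hydrogen in place of methoxymethoxy on a saturated chain carbon, two bonds along the chain from an oxygen on an aromatic ring

Within the data shown here, no step between measured compounds is available, so the size of this change is not anchored by any pair in the set. An upward step is expected in this assay, because compound 2 sits only at the limit < 0.02 h and cannot go lower. The step is estimated as an at least 7.5-fold higher number from compound 2 to compound 3 (0.87 log units; beyond the scatter), beyond the scatter, in the upward direction. Compound 3 is expected to give 0.15 h, with a range from 0.03 h to 0.6 h.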

Compound 3, half-life: < 0.02 h
Compound 3 was reported as a limit; the forecaster's own chance of this, stated with the estimate: 20%; middle value at least 7.5-fold (0.87 log units) away from the limit.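

In this assay compound 3 gives < 0.02 h, a limit of the assay and not a number. With compound 2 also at a limit, no step can be read between compound 2 and compound 3, which share one reading: the limit of < 0.02 h in this assay, at which 2 of the 3 values shown sit. Left open is whether going from 2-(methoxymethoxy)ethoxy to ethoxy changes the half-life at all, and by how much.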